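The source may hold more compounds than are shown below. What is called first, only, known or untested is meant among the compounds shown, and "the series" means these compounds.

Compound 1 `CC1(C)[C@H]2CC[C@]1(C)[C@H](OC(=O)CN1CCCCC1)C2` gives 141000 nM in an ADME assay on HEK-293T cells (Homo sapiens) for cytotoxicity, read by MTT assay, with a stated time of 48 h (a higher number here means that more compound is tolerated, a lower number that less compound is tolerated), the highest of the three numbers shown, though the other two lie within the scatter of it: compound 2 `CC1(C)[C@H]2CC[C@]1(C)[C@H](OC(=O)CCCN1CCCCC1)C2` gives 74800 nM and compound 3 `CC1CCN(CCCCC(=O)O[C@@H]2C[C@@H]3CC[C@@]2(C)C3(C)C)CC1` gives 73000 nM. Compound 4 `CN1CCN(CC(=O)O[C@@H]2C[C@@H]3CC[C@@]2(C)C3(C)C)CC1` is not yet measured; it differs from compound 1 by 4-methylpiperazin-1-yl in place of piperidin-1-yl on a saturated chain carbon bound to a carbonyl carbon. Going by the values given here, the only measured one-place step, a 1.0-fold lower number from compound 2 to compound 3 (0.01 log units; within the scatter), swaps a ring on a saturated chain carbon, three bonds along the chain from a carbonyl carbon, and stays within the scatter; no measured step swaps a ring on the carbon bound to the carbonyl. Compound 4 is therefore expected to stay near compound 1, a step of about a 1.2-fold lower number from compound 1 to compound 4 (0.07 log units; within the scatter), nothing beyond the scatter. The estimate for compound 4 is 120000 nM, expected to fall between 60000 nM and 240000 nM.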

Compound 4, half-maximal cytotoxic concentration: 313000 nM
Compound 4: the middle estimate sits 2.6-fold (0.42 log units) below what was measured; measured number above the stated range.
By their numbers in this assay, from the lowest: compounds 3, 2 and 1 (each within the scatter of the next); then compound 4.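

Going by these compounds alone, at the saturated chain carbon bound to a carbonyl carbon, swapping the ring does shift the number in this assay: 4-methylpiperazin-1-yl in place of piperidin-1-yl gives a 2.2-fold higher number from compound 1 to compound 4 (0.35 log units; beyond the scatter) and is the first step here to pass the scatter. Within the data shown here, the only earlier ring swap, farther along the chain, gave a 1.0-fold lower number from compound 2 to compound 3 (0.01 log units; within the scatter) and stayed within it. No measurement shown explains the rise.

Still open, on these data alone, is whether the second ring nitrogen or the methyl carries this step, which piperazin-1-yl or morpholin-4-yl on the same carbon could help separate. As far as these compounds go, whether 4-methylpiperazin-1-yl on a longer chain behaves alike also remains open.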